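The source may report more compounds than this note shows. Statements on the series, on what has been measured and on what is new or still open speak of the compounds shown alone.

Three compounds have been measured so far:

compound 1, `CC(=O)OC/C(=C\c1ccccc1)C(=O)c1ccccc1`, which in a functional assay on SW1573 cells (Homo sapiens) for inhibition, read by sulforhodamine B assay, with a stated time of 48 h (on this read-out higher numbers stand for weaker inhibition of growth and lower numbers for stronger inhibition of growth), gives 4800 nM;
compound 2, `CC(=O)OC/C(=C\c1ccc(Cl)cc1)C(=O)c1ccccc1`, which in this assay gives 2600 nM;
compound 3, `CC(=O)OC/C(=C/c1ccc(Cl)cc1)C(=O)c1ccc(Cl)cc1`, which in this assay gives 5300 nM.

Compound 2 differs from compound 1 by chloro in place of hydrogen on an aromatic carbon, and this step, a 1.8-fold lower number from compound 1 to compound 2 (0.27 log units; within the scatter), is within the scatter. How the core of compound 3 differs from that of compound 1 is not broken down here; compound 3 and compound 1 give numbers within the scatter of each other, while compound 2 gives a lower number than compound 3, a gap beyond the scatter.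

Compound 4, `CC(=O)OC/C(=C/c1ccc(Cl)cc1Cl)C(=O)c1ccc(Cl)cc1`, has not yet been measured. It differs from compound 3 by chloro in place of hydrogen on an aromatic carbon. Going by the values given here, this is the same kind of change as the one from compound 1 to compound 2, but not the same: there the entering chloro sat para to a large group, here it sits ortho to a large group and meta to a chloro group. Among the compounds with values here, the only guide to the size of the step is the earlier one, a 1.8-fold lower number from compound 1 to compound 2 (0.27 log units; within the scatter), so in this assay compound 4 is expected to show a step of about a 1.5-fold lower number from compound 3 to compound 4 (0.18 log units; within the scatter), with the different surroundings of the new chloro leaving the direction uncertain. For compound 4 the expected value is therefore 3500 nM, estimated to lie between 1500 nM and 8000 nM.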

Compound 4, concentration for 50% growth inhibition: 21000 nM
Beside the measured number, compound 4's estimate is 6.0-fold (0.78 log units) below it, and the stated range ends below it.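

In this assay, the change from 4-chlorophenyl to 2,4-dichlorophenyl gives a 4.0-fold higher number from compound 3 to compound 4 (0.60 log units; beyond the scatter), so here chloro in place of hydrogen on an aromatic carbon goes with weaker inhibition of growth. Set beside the earlier step, this shows that the size of the change does not carry over from one core to the other in this series: the same change on two cores in this assay, a 1.8-fold lower number (0.27 log units; within the scatter) from compound 1 to compound 2 and a 4.0-fold higher number (0.60 log units; beyond the scatter) from compound 3 to compound 4, 7.3-fold (0.86 log units) apart, beyond the scatter of two such steps

What this does not show is why the two steps part, since they differ in the core and also in where the chloro enters, here ortho to a large group and meta to a chloro group, and a single pair of steps cannot separate these, nor can it give a general rule for the series.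

The compounds shown leave open whether a fluoro or methoxy group entering at the same place on the core of compound 3 would follow the step seen with chloro. Going by these compounds, it also remains open whether the step would hold on a core with a free hydroxyl, an amine or a longer ester chain in place of the acetate.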